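The source may hold more compounds than are shown below. What is called first, only, known or untested is meant among the compounds shown, and "the series" means these compounds.

Measured in a functional assay on BT-483 cells (Homo sapiens) for cytotoxicity, read by MTT assay, with a stated time of 24 h; a higher number here means a weaker inhibitor, a lower number a stronger inhibitor:

Compound 1 `CCNc1cc(-c2ccc(NC(=O)Nc3ccc(C(F)(F)F)cc3)cc2C(F)(F)F)ccn1`: 16400 nM
Compound 2 `O=C(Nc1cccc(Cl)c1)Nc1ccc(-c2ccnc(NCC3CC3)c2)c(C(F)(F)F)c1`: > 30000 nM (a limit)

Only compound 1 has a true number among the measured compounds. Compound 2 gives > 30000 nM, which is a limit of this assay and not a number. Going by these compounds, that leaves compound 2 at the limit of > 30000 nM in this assay, at which 1 of the 2 values shown sits, so its exact position remains unknown.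

Compound 3 `O=C(Nc1ccc(C(F)(F)F)cc1)Nc1ccc(-c2ccnc(NCC3CC3)c2)c(C(F)(F)F)c1` departs from compound 2 at a single place, with 4-(trifluoromethyl)phenyl in place of 3-chlorophenyl on an amide-type nitrogen. Among the compounds with values here, no measured pair isolates this change, so any forecast rests on thin evidence. Compound 1 also carries the 4-(trifluoromethyl)phenyl group and gives 16400 nM, so a modest move towards a lower number is expected. The result could also stay at the limit. The expected size of this move is an at least 1.8-fold lower number from compound 2 to compound 3 (0.27 log units; that floor lies within the scatter). For compound 3 the estimated value is 16000 nM, with an expected range of 7000 nM to 30000 nM.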

Compound 3, half-maximal inhibitory concentration: > 30000 nM
Compound 3 was reported as a limit (the forecaster's own chance of this, stated with the estimate: 35%); middle value at least 1.8-fold (0.27 log units) away from the limit.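

In this assay compound 3 gives > 30000 nM, which is a limit of the assay and not a number, so 4-(trifluoromethyl)phenyl on the amide-type nitrogen does not by itself bring the cyclopropyl-bearing compound to a true number. Going by these compounds, the step from 3-chlorophenyl to 4-(trifluoromethyl)phenyl cannot be read, and the size of this change stays unknown because both of its ends are limits: the limit of > 30000 nM in this assay, at which 2 of the 3 values shown sit. The one readable comparison concerns the chain instead: with 4-(trifluoromethyl)phenyl held fixed, cyclopropyl in place of methyl on a saturated chain carbon bound to a nitrogen on an aromatic ring gives an at least 1.8-fold higher number from compound 1 to compound 3 (0.26 log units; that floor lies within the scatter), so the chain change is not shown to exceed the usual scatter.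

The compounds shown leave open how far above the limit compound 2 and compound 3 truly lie, and so whether either aryl group on the urea differs from the other at all. They also leave open what a longer chain such as n-propyl, or a plain amine, would do in place of the groups on that aromatic nitrogen.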